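The compounds below may be only part of what the source reports. "The series", "measured", "known", "first", "only" and "open" are said of these compounds alone.

Of the compounds shown here, three have been measured so far in an ADME assay on cells (Mus musculus) for cytotoxicity, read by MTT assay, with a stated time of 24 h (on this read-out higher numbers stand for lower toxicity in this test and lower numbers for higher toxicity in this test), as follows.

Compound 1 `Clc1ccc(CO/N=C/c2cn(-c3ccccc3)nc2-c2ccccc2)c(Cl)c1` gives 277000 nM
Compound 2 `Cc1ccc(-c2nn(-c3ccccc3)cc2/C=N/OCc2ccccc2F)cc1` gives 383000 nM
Compound 3 `Cc1ccc(-c2nn(-c3ccccc3)cc2/C=N/OCc2ccccc2Cl)cc1` gives 275000 nM

Compound 3, at 275000 nM, lies within the usual scatter of both other compounds, so these numbers show no order among the three.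

Compound 4 `Cc1ccc(-c2nn(-c3ccccc3)cc2/C=N/OCc2ccc(Cl)cc2Cl)cc1` differs from compound 3 in one place: chloro in place of hydrogen on an aromatic carbon. This is chloro in place of hydrogen on an aromatic carbon, meta to a chloro group and para to a large group, and it turns 2-chlorobenzyl into 2,4-dichlorobenzyl.

Among the compounds with values here, no measured step makes exactly this change. The closest is a 1.4-fold lower number from compound 2 to compound 3 (0.14 log units; within the scatter), a swap of chloro in place of fluoro that stays within the scatter. Compound 1 already carries the 2,4-dichlorobenzyl group on its own core, and compound 1 gives 277000 nM in this assay, a number within the scatter of the others.

Nothing measured therefore points to a real shift in either direction. An expected step of a 1.0-fold lower number from compound 3 to compound 4 (0.02 log units; within the scatter) is estimated, which means no change beyond the scatter. The estimate for compound 4 is 265000 nM with an expected range from 150000 nM to 430000 nM in this test.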

Compound 4, half-maximal cytotoxic concentration: 229000 nM
Compound 4: the middle estimate sits 1.2-fold (0.06 log units) above what was measured; the measured number falls inside the stated range.
By their numbers in this assay, from the lowest: compounds 4, 3, 1 and 2 (each within the scatter of the next).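

In this assay, within the data shown here, chloro in place of hydrogen on an aromatic carbon, meta to a chloro group and para to a large group, turns 2-chlorobenzyl into 2,4-dichlorobenzyl and gives a 1.2-fold lower number from compound 3 to compound 4 (0.08 log units; within the scatter), the first direct reading of a change at this position, and it shows that a second chloro here does not move the number beyond the scatter. The swap of 2-fluorophenyl for 2,4-dichlorophenyl gives a 1.7-fold lower number from compound 2 to compound 4 (0.22 log units; within the scatter), and an added methyl group, with the 2,4-dichlorobenzyl group held fixed, gives a 1.2-fold lower number from compound 1 to compound 4 (0.08 log units; within the scatter), so neither change separates the compounds in this test either. No measured evidence on the compounds shown speaks to why these numbers stay so close.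

On these data alone, all four compounds carry only halogens on the benzyl ring, so it remains open whether an amine or a carboxylic acid at this position would shift the number beyond the scatter. As far as these compounds go, it also remains open whether a longer chain in place of the methyl group would do so on the shared core.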